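Pyrazoline sulfonamides: replacing the styryl arm with dimethoxyphenyl

A few compounds are considered here, and "the series" means these few. Any claim that something is new, unique, unknown or untested is made for them only; others in the source may bear on it.

Measured compounds:
compound 1 `Cc1cc(O)c(C2=NN(c3ccc(S(N)(=O)=O)cc3)C(c3ccccc3Cl)C2)cc1Cl` — 3090 nM
compound 2 `Cc1cc(O)c(C2=NN(c3ccc(S(N)(=O)=O)cc3)C(/C=C/c3ccccc3)C2)cc1Cl` — 6690 nM

Among the measured compounds shown here, compound 2 has the highest of the two numbers in a functional assay on RXF 393 cells (Homo sapiens) for antiproliferative activity, with a stated time of 48 h; a lower number here means a stronger inhibitor of growth, a higher number a weaker inhibitor of growth; its nearest neighbour is compound 1, and the one measured step, a 2.2-fold higher number from compound 1 to compound 2 (0.34 log units; beyond the scatter), is modest yet beyond the scatter. Compound 3 `COc1ccc(C2CC(c3cc(Cl)c(C)cc3O)=NN2c2ccc(S(N)(=O)=O)cc2)cc1OC` is not yet measured. It differs from compound 2 as follows: 3,4-dimethoxyphenyl in place of 2-phenylethenyl on a saturated ring carbon. For the measured compounds named here, this step has no direct precedent here. Going by the values given here, the only step that bears on it is a 2.2-fold higher number from compound 1 to compound 2 (0.34 log units; beyond the scatter), which accompanied the loss of a six-membered aromatic ring of carbon only on the saturated ring carbon and the entry of a double bond outside aromatic rings. As far as these compounds go, compound 3 reverses that feature, so a step back toward the number of compound 1 is expected, of about a 1.9-fold lower number from compound 2 to compound 3 (0.28 log units; within the scatter) in this assay, though the change from 2-chlorophenyl to 3,4-dimethoxyphenyl is untested and widens the range. Compound 3 is expected to give 3500 nM, within 1500 nM to 9000 nM.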

Compound 3, concentration for 50% growth inhibition: 2880 nM
The estimate for compound 3 lay 1.2-fold (0.08 log units) above the measured number; the measured number falls inside the stated range.
By their numbers in this assay, from the lowest: compounds 3 and 1 (each within the scatter of the next); then compound 2.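

In this assay, the saturated ring carbon next to the ring nitrogen tolerates more than one six-membered aromatic ring of carbon only: a 1.1-fold lower number from compound 1 to compound 3 (0.03 log units; within the scatter) leaves 3,4-dimethoxyphenyl and 2-chlorophenyl indistinguishable. With a 2.3-fold lower number from compound 2 to compound 3 (0.37 log units; beyond the scatter) added to a 2.2-fold higher number from compound 1 to compound 2 (0.34 log units; beyond the scatter), 2-phenylethenyl now separates from both aryl groups, and none of the three compounds goes against this grouping. Nothing measured here accounts for the separation of 2-phenylethenyl from the two aryl groups.

Open, as far as these compounds go, is whether a group without an aromatic ring on this carbon, such as a propyl chain or a dimethylamino-bearing chain, would stay with compound 2 or with compound 3. Also open, from the compounds shown here alone, is whether a single methoxy group, as in 4-methoxyphenyl, would behave as 3,4-dimethoxyphenyl does.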